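This account rests on a few compounds, and the source may have more. Where it says the series, first, only, none or still open, it means among the compounds named here.

Measured so far, in an ADME assay on HEK-293T cells (Homo sapiens) for cytotoxicity, read by luminescence, with a stated time of 24 h (on this read-out lower numbers stand for higher toxicity in this test and higher numbers for lower toxicity in this test), each value being a limit of the assay and not a number:

compound 1 `COc1ccc(Cn2c(C(=O)N3CCC(C(=O)O)CC3)cc3sccc32)cc1`: > 100000 nM
compound 2 `COc1ccc(Cn2c(C(=O)N3CCC(C(=O)NCc4ccccc4)CC3)cc3sccc32)cc1`: > 100000 nM
compound 3 `COc1ccc(Cn2c(C(=O)N3CCC(C(=O)NC(C)c4ccccc4)CC3)cc3sccc32)cc1`: > 100000 nM

Compound 3 gives > 100000 nM, which is a limit. It therefore has no exact place on the scale, and it does not stand apart from the other two compounds. The series as a whole shows (the limit of > 100000 nM in this assay, at which 3 of the 3 values shown sit).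

Compound 4 `COc1ccc(Cn2c(C(=O)N3CCC(C(=O)NC4CC4)CC3)cc3sccc32)cc1` keeps the shared core and differs from compound 3 in a single group: cyclopropyl in place of 1-phenylethyl on an amide-type nitrogen. In words, cyclopropyl stands in place of 1-phenylethyl on an amide-type nitrogen.

For the measured compounds named here, three measured steps bear on this change. Going by the values given here, the first is a step that the two limits leave unreadable from compound 1 to compound 2, the second is a step that the two limits leave unreadable from compound 1 to compound 3, and the third, which alters the group that now leaves, is a step that the two limits leave unreadable from compound 2 to compound 3. None of them has a readable size, so they offer no measured effect to carry over. They do show that changing this part of the molecule has not yet produced a number in this assay.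

The expected change is therefore none beyond the scatter, stated here as a number no higher from compound 3 to compound 4 (the limit leaves the size open). For compound 4 the estimated value is 100000 nM, with an expected range of 50000 nM to 200000 nM.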

Compound 4, half-maximal cytotoxic concentration: 21400 nM
Estimate against measurement, compound 4: 4.7-fold (0.67 log units) above; the measured number lies below the stated range.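

In this assay, for the compounds shown here, cyclopropyl on the amide-type nitrogen gives the first readable number, with an at least 4.6-fold lower number from compound 3 to compound 4 (0.66 log units; beyond the scatter), and a lower number here stands for higher toxicity in this test. The comparison with benzyl gives an at least 4.6-fold lower number from compound 2 to compound 4 (0.66 log units; beyond the scatter), and the comparison with the hydroxy on the carbonyl carbon of compound 1 gives an at least 4.6-fold lower number from compound 1 to compound 4 (0.66 log units; beyond the scatter), each size being a minimum set by a limit of the assay. An amide-type nitrogen alone does not bring the number down, as compound 2 and compound 3 also carry one and remain at the limit, so the group on that nitrogen matters in this test: the limit of > 100000 nM in this assay, at which 3 of the 4 values shown sit.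

The steps among compound 1, compound 2 and compound 3 cannot be read, and the shown change removes the six-membered aromatic ring and replaces it with a three-membered ring in one move, leaving open which of these differences counts. Going by these compounds, it also remains open whether a cyclobutyl or cyclopentyl ring, an open chain such as isopropyl, or a group carrying an amine on the same nitrogen would give a similar number.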